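Phenyl for methyl at the amide-linked chain carbon

This account rests on a few compounds, and the source may have more. Where it says the series, first, only, none or still open, it means among the compounds named here.

Measured compounds:
- compound 1 `CCCCCCCCC(CCCCCCCCC(=O)OC)SCC(=O)N[C@@H](C)C(=O)OC`: 98700 nM
- compound 2 `CCCCCCCCC(CCCCCCCCC(=O)OC)SCC(=O)N[C@@H](CC(C)C)C(=O)OC`: 152000 nM

Compound 1 gives the lowest of the two numbers in a functional assay on MDA-MB-231 cells (Homo sapiens) for cytotoxicity, read by MTT assay; on this read-out higher numbers stand for weaker inhibition and lower numbers for stronger inhibition. Its nearest neighbour is compound 2, and the step of a 1.5-fold higher number from compound 1 to compound 2 (0.19 log units; within the scatter) does not rise above the scatter, so the two measured compounds are not separated on this read-out.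

Compound 3 `CCCCCCCCC(CCCCCCCCC(=O)OC)SCC(=O)N[C@H](C(=O)OC)c1ccccc1` is not yet measured. Relative to compound 1 the change is phenyl in place of methyl on a saturated chain carbon bound to an amide-type nitrogen and a carbonyl carbon. Among the measured compounds shown here, the only measured step that touches the same chain carbon is the one from compound 1 to compound 2, where a larger group entering at a neighbouring position of the same fragment left the number within the scatter. For the measured compounds named here, no measured step places an aromatic group at this carbon, so the present change is not covered directly by the data.

On that basis a step in this assay of roughly the size of a 1.3-fold higher number from compound 1 to compound 3 (0.12 log units; within the scatter) is expected from compound 1 to compound 3, with no clear direction beyond the scatter. For compound 3 the estimate in this assay is 130000 nM, with a range from 60000 nM to 280000 nM.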

Compound 3, half-maximal inhibitory concentration: 38600 nM
Compound 3: the middle estimate sits 3.4-fold (0.53 log units) above what was measured, outside the stated range (below it).
By their numbers in this assay, from the lowest: compound 3; then compounds 1 and 2 (each within the scatter of the next).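

In this assay, among the compounds shown here, the saturated chain carbon bound to an amide-type nitrogen and a carbonyl carbon proves responsive to substitution: phenyl in place of methyl gives a 2.6-fold lower number from compound 1 to compound 3 (0.41 log units; beyond the scatter) and is the first change to clear the scatter. Phenyl in place of isobutyl gives a 3.9-fold lower number from compound 2 to compound 3 (0.60 log units; beyond the scatter) as well, so compound 3 stands apart from both alkyl-bearing compounds, which themselves remain unseparated, though both steps are modest and compound 3 still reads 38600 nM in this assay. Nothing measured on these compounds accounts for this separation.

On these data alone, whether the step belongs to the aromatic ring or to any ring at this carbon remains open: cyclohexyl in place of phenyl would address that, and benzyl would show whether the ring has to be bound directly to the chain carbon. Also open, as far as these compounds go, is whether the step persists with a carboxylic acid in place of the methoxycarbonyl group, and whether a substituted phenyl, such as a fluorophenyl, moves the number any further than phenyl does.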